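The source may report more compounds than this note shows. Statements on the series, on what has been measured and on what is new or still open speak of the compounds shown alone.

Measured compounds:
compound 1 `COc1ccc(S(=O)(=O)N(C)CCOCC(=O)N(C)Cc2ccc(C3=NCCN3)cc2)c(C)c1`, giving 8.6 in a functional assay on Umbilical vein for antagonist activity at B1 bradykinin receptor (Homo sapiens), using Schild analysis, with a stated time of 30 min; on this read-out higher numbers stand for higher potency (the scale is a negative logarithm) and lower numbers for lower potency
compound 2 `COc1cc(C)c(S(=O)(=O)N(C)CCOCC(=O)N2CCC(C3CCN(C)CC3)CC2)c(C)c1`, giving 9 in this assay

Compound 1 holds the lower of the two numbers; compound 2 stands above it by a gap beyond the usual scatter. Going by the values given here, no two measured compounds differ in a single place, so no measured step guides the next change. Compound 3 `CN(Cc1ccc(C2=NCCN2)cc1)C(=O)COCCN(C)S(=O)(=O)c1c(Cl)cccc1Cl` carries 2,6-dichlorophenyl in place of 4-methoxy-2-methylphenyl on a sulfonyl sulfur. Lacking any measured step of this kind, only a small shift upward in this assay is expected, not beyond the scatter, so the expected step is a number 0.10 log units higher from compound 1 to compound 3 (within the scatter). For compound 3 the estimate is 8.7, within 8 to 9.4.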

Compound 3, negative logarithm of the antagonist equilibrium constant: 8.5
The estimate for compound 3 lay 0.20 log units above the measured number; the range from low to high includes it.
By their numbers in this assay, from the lowest: compounds 3 and 1 (each within the scatter of the next); then compound 2.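

With the rest of compound 1 held fixed, 2,6-dichlorophenyl in place of 4-methoxy-2-methylphenyl on a sulfonyl sulfur gives a number 0.10 log units lower from compound 1 to compound 3 (within the scatter) in this assay. This position therefore tolerates the loss of the methoxy and methyl groups and the entry of two chlorine atoms, with no step beyond the scatter. No measured evidence bears on this result.

Open, on these data alone, is whether a non-aromatic group such as cyclohexyl, or a phenyl ring carrying an amine, would hold this level on the sulfonyl sulfur. Compound 2 differs from both compounds in more than one place, so whether this tolerance carries over to it cannot be read.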